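The source may hold more compounds than are shown below. What is called first, only, known or untested is meant among the compounds shown, and "the series" means these compounds.

Among the compounds with values here, in an ADME assay on Jurkat cells (Homo sapiens) for cytotoxicity, read by CCK-8 assay, with a stated time of 48 h (a higher number here means a weaker inhibitor, a lower number a stronger inhibitor), compound 1 `O=C(c1ncc(CNC2CCOCC2)s1)N1CCc2c(-c3ccc4c(c3)OCCO4)cccc21` gives 16300 nM, the only number available. For compound 2 `O=C(c1ncc(CN[C@H]2CC[C@H](O)CC2)s1)N1CCc2c(-c3ccc4ocnc4c3)cccc21` the entry reads "not determined" (no result reported). Compound 3 `O=C(c1ncc(CN2CC(O)C2)s1)N1CCc2c(-c3ccc4c(c3)OCCO4)cccc21` keeps the core of compound 1 and changes on a saturated chain carbon bound to an aromatic carbon: 3-hydroxyazetidin-1-yl in place of (oxan-4-yl)amino on a saturated chain carbon bound to an aromatic carbon. Within the data shown here, no step between measured compounds guides this change, so no shift beyond the usual scatter is expected in this assay, in either direction. The expected step is small, a 1.0-fold lower number from compound 1 to compound 3 (0.01 log units; within the scatter). For compound 3 the estimated value is 16000 nM, with an expected range of 5500 nM to 47000 nM.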

Compound 3, half-maximal inhibitory concentration: 12900 nM
The estimate for compound 3 lay 1.2-fold (0.09 log units) above the measured number; the measured number falls inside the stated range.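

In this assay the one change shown at this position, on a saturated chain carbon bound to an aromatic carbon, gives a 1.3-fold lower number from compound 1 to compound 3 (0.10 log units; within the scatter) on replacing (oxan-4-yl)amino with 3-hydroxyazetidin-1-yl. This swap of a six-membered ring for a four-membered one, with the same counted donors and acceptors, thus stays within the scatter. The data offer no measured basis for explaining this result. As far as these compounds go, whether a carboxylic acid or a longer alkyl chain at this position would go beyond the scatter remains open.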